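The source may hold more compounds than are shown below. What is called first, only, known or untested is meant among the compounds shown, and "the series" means these compounds.

Measured so far:
compound 1, `CC1=C(CC(=O)OCCC[Se]C(F)(F)F)c2cc(F)ccc2/C1=C\c1ccc([S+](C)[O-])cc1`, in a functional assay on Caco-2 cells (Homo sapiens) for cytotoxicity, read by MTT assay, with a stated time of 72 h (a higher number here means a weaker inhibitor, a lower number a stronger inhibitor), compound 1 gives 16400 nM.
compound 2, `COc1ccc2c(c1)c(CC(=O)OCCC[Se]C#N)c(C)n2C(=O)c1ccc(Cl)cc1`, in this assay compound 2 gives 32400 nM.
compound 3, `Cc1cccc(Nc2ccccc2C(C)C(=O)OCCC[Se]C(F)(F)F)c1C`, in this assay compound 3 gives 13300 nM.

Compound 3 has the lowest of the three numbers. Its gap to compound 1 is within the usual scatter of repeated measurements, so those two cannot be told apart; its gap to compound 2 lies beyond the scatter, so compound 3 stands as the stronger of that pair. For the measured compounds named here, no two of the three compounds differ in a single place, so no measured step is available.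

Compound 4, `Cc1cccc(Nc2ccccc2C(C)C(=O)OCCC[Se]C#N)c1C`, departs from compound 3 by cyano in place of trifluoromethyl on a selenium. Going by the values given here, the only other compound carrying the cyano on selenium, compound 2, sits on a different core, so its value gives no direct guide to the size of this change.

The author expects the step from compound 3 to compound 4 in this assay to be small, at most a modest rise, and quite possibly none beyond the scatter: a 1.4-fold higher number from compound 3 to compound 4 (0.13 log units; within the scatter). The estimate for compound 4 in this assay is 18000 nM, with a range from 7000 nM to 45000 nM.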

Compound 4, half-maximal inhibitory concentration: 17200 nM
For compound 4 the middle estimate is 1.0-fold (0.02 log units) above the measured one; measured number inside the range.
By their numbers in this assay, from the lowest: compounds 3, 1, 4 and 2 (each within the scatter of the next, the first and the last beyond it).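

In this assay, the series gains its first measured step at this position, and replacing trifluoromethyl with cyano on a selenium gives a 1.3-fold higher number from compound 3 to compound 4 (0.11 log units; within the scatter) on the core the two compounds share. For the compounds shown here, at this selenium, whose other neighbour is a saturated chain carbon, a group of 4 heavy atoms and no hydrogen-bond acceptor thus gives way to one of 2 heavy atoms and 1 hydrogen-bond acceptor, with no change beyond the scatter, something the earlier compounds, which differ in more than one place, could not show. No measurement of any property of these compounds bears on why the read-out stays within the scatter.

As far as these compounds go, it remains open whether the same exchange would stay as small on the core of compound 1 or the core of compound 2, for neither compound has a partner here that differs only on the selenium. Also open, from the compounds shown here alone, is how a methyl or phenyl group on the selenium, a longer chain carrying it, or a carboxylic acid in place of the ester would read in this assay.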